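Moving the Fluorine from the 3- to the 4-Position

A few compounds are considered here, and "the series" means these few. Any claim that something is new, unique, unknown or untested is made for them only; others in the source may bear on it.

Measured in an ADME assay on MCF7-DOX cells (Homo sapiens) for cytotoxicity, read by MTT assay, with a stated time of 48 h; on this read-out higher numbers stand for weaker inhibition and lower numbers for stronger inhibition:
compound 1, `COc1cc(OC)c(C(=O)/C=C/c2cccc(F)c2)c(O)c1CC=C(C)C`, gives 45400 nM.
compound 2, `COc1cc(OC)c(C(=O)/C=C/c2cccc(N3CCN(C(=O)OC(C)(C)C)CC3)c2)c(O)c1CC=C(C)C`, gives 42600 nM.

Compound 1 stands at the highest of the two numbers, but compound 2 lies within the scatter of it, so the two show the same weak inhibition and no order between them can be read. Among the compounds with values here, no pair of measured compounds that differ in a single place is available here, so no measured step sets a scale for what a small change does.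

The unmeasured compound 3, `COc1cc(OC)c(C(=O)/C=C/c2ccc(F)cc2)c(O)c1CC=C(C)C`, keeps every atom of compound 1 and only joins them differently: 4-fluorophenyl in place of 3-fluorophenyl on a double-bonded chain carbon bound to a double-bonded chain carbon. The fluorine stays on the phenyl ring, and the whole rest of the molecule is untouched. Without a measured step to lean on, the expectation for compound 3 in this assay is a step from compound 1 no larger than the usual scatter, in no particular direction, with the number expected to stay weak like both measured compounds. Compound 3 is therefore expected to give 40000 nM, within 15000 nM to 110000 nM. That estimate means a step of a 1.1-fold lower number from compound 1 to compound 3 (0.05 log units; within the scatter), expected to sit within the scatter.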

Compound 3, half-maximal inhibitory concentration: 53700 nM
Compound 3: middle estimate off by 1.3-fold (0.13 log units), on the low side, and the stated range covers the measured number.
By their numbers in this assay, from the lowest: compounds 2, 1 and 3 (each within the scatter of the next).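

In this assay the series now has its first measured step between compounds that differ in one place: 4-fluorophenyl in place of 3-fluorophenyl gives a 1.2-fold higher number from compound 1 to compound 3 (0.07 log units; within the scatter) and so stays within the scatter. At this place, on a double-bonded chain carbon bound to a double-bonded chain carbon, the two fluorophenyl groups cannot be told apart by this read-out, and both compounds remain weak inhibitors. Nothing measured here bears on the reason for this result.

The compounds shown leave open whether the fluorine itself matters, as they include neither a plain phenyl group at this place nor a ring carrying a hydroxyl, an amine or a carboxylic acid instead. They also leave open whether a change elsewhere on the shared core, such as a longer chain or a different group in place of one of its methoxy groups, could bring the number down to a clearly stronger level of inhibition.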